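From Methoxy to Trifluoromethyl on the Aromatic Ring

The source may hold more compounds than are shown below. What is called first, only, known or untested is meant among the compounds shown, and "the series" means these compounds.

Of the compounds shown here, two sharing one core have been tested in a functional assay on A549 cells (Homo sapiens) for inhibition, read by sulforhodamine B assay, with a stated time of 48 h; on this read-out lower numbers stand for stronger inhibition of growth and higher numbers for weaker inhibition of growth. Compound 1 `COC(=O)[C@@]1(C)CCC=C2[C@@H]1CC[C@@H](C)[C@]2(C)Cc1c[nH]c2ccc(F)cc12` carries a fluoro group on an aromatic carbon, and in this assay compound 1 gives 6200 nM. Compound 2 `COC(=O)[C@@]1(C)CCC=C2[C@@H]1CC[C@@H](C)[C@]2(C)Cc1c[nH]c2ccc(OC)cc12` carries a methoxy group in the same place, and in this assay compound 2 gives 2200 nM. Within the data shown here, the single change between them gave a 2.8-fold lower number from compound 1 to compound 2 (0.45 log units; beyond the scatter), so compound 2 stands with the lowest of the two numbers measured so far, with compound 1 the nearest and higher one.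

Compound 3 `COC(=O)[C@@]1(C)CCC=C2[C@@H]1CC[C@@H](C)[C@]2(C)Cc1c[nH]c2ccc(C(F)(F)F)cc12` differs from compound 2 in one place: trifluoromethyl in place of methoxy on an aromatic carbon of a six-membered aromatic ring of carbon only, part of a fused system of two rings. Among the measured compounds shown here, no measured step involves a trifluoromethyl group. For the measured compounds named here, the only step known, a 2.8-fold lower number from compound 1 to compound 2 (0.45 log units; beyond the scatter), concerns a different exchange on that carbon and shows that the group there can shift the number modestly. With no closer guide, the step from compound 2 to compound 3 is expected to be a 1.8-fold higher number from compound 2 to compound 3 (0.26 log units; within the scatter), a small change that may stay within the scatter. Compound 3 is therefore estimated at 4000 nM in this assay, with a likely range from 1500 nM to 12000 nM.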

Compound 3, concentration for 50% growth inhibition: 15000 nM
Estimate against measurement, compound 3: 3.8-fold (0.57 log units) below; the whole stated range lies below it.
By their numbers in this assay, from the lowest: compound 2; then compound 1; then compound 3.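

Trifluoromethyl is the least favourable of the three groups seen on this aromatic carbon, and a higher number here means weaker inhibition of growth. Replacing methoxy with trifluoromethyl gives a 6.8-fold higher number from compound 2 to compound 3 (0.83 log units; beyond the scatter) and shows that this exchange can cost real activity, while replacing fluoro with trifluoromethyl gives a 2.4-fold higher number from compound 1 to compound 3 (0.38 log units; beyond the scatter) and shows that the two fluorine-bearing groups are not interchangeable here. These numbers give an order of compound 2, compound 1 and compound 3 from lowest to highest, but no accompanying measurement explains that order.

Methoxy is the only oxygen-bearing group among these compounds, and it gives the lowest number, so three compounds cannot tell whether that oxygen matters or whether something else about the group sets the order. A hydroxyl group, a longer ethoxy chain or an amine on the same aromatic carbon would help to show whether the lower number seen with methoxy extends to other groups containing oxygen or nitrogen.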